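The source may report more compounds than this note shows. Statements on the series, on what has been measured and on what is new or still open speak of the compounds shown alone.

In a functional assay on ECa-109 cells for inhibition, with ECa-109 cell line (Homo sapiens) as the target, read by sulforhodamine B assay (a higher number here means a weaker inhibitor, a lower number a stronger inhibitor), compound 2 `O=C1C(Nc2ccccc2F)=CC(=O)c2c1nc1n2[C@H]2OC[C@@H](O)[C@H]2OC1` gives 2660 nM and compound 3 `CCc1ccc(NC2=CC(=O)c3nc4n(c3C2=O)[C@H]2OC[C@@H](O)[C@H]2OC4)cc1` gives 3080 nM, two values within the scatter of each other. Compound 1 `CCCc1ccc(NC2=CC(=O)c3nc4n(c3C2=O)[C@H]2OC[C@@H](O)[C@H]2OC4)cc1` reads > 4000 nM, which is a limit of the assay and not a number. Compound 2 therefore sits level with compound 3 among the numbers available.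

Compound 4 `O=C1C(Nc2ccc(C(F)(F)F)cc2)=CC(=O)c2c1nc1n2[C@H]2OC[C@@H](O)[C@H]2OC1` differs from compound 2 on the amine nitrogen: 4-(trifluoromethyl)phenyl in place of 2-fluorophenyl on an amine nitrogen, that is, 4-(trifluoromethyl)phenyl in place of 2-fluorophenyl. For the measured compounds named here, the only measured step is an at least 1.2-fold lower number from compound 1 to compound 3 (0.11 log units; that floor lies within the scatter). It starts from the limit of > 4000 nM in this assay, at which 1 of the 3 values shown sits, so its size is a floor. It concerns a saturated chain and does not test the change made here. Going by the values given here, with that small step as the only guide, no shift beyond the scatter is expected in this assay, and no direction can be assigned. An estimated step of a 1.1-fold higher number from compound 2 to compound 4 (0.05 log units; within the scatter) is expected. For compound 4 the estimated value is 3000 nM, with an expected range of 1300 nM to 6000 nM.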

Compound 4, half-maximal inhibitory concentration: 2250 nM
Compound 4: the middle estimate sits 1.3-fold (0.12 log units) above what was measured; measured number inside the range.
By their numbers in this assay, from the lowest: compounds 4, 2 and 3 (each within the scatter of the next). At a limit, above all of these: compound 1.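

Replacing 2-fluorophenyl with 4-(trifluoromethyl)phenyl on the amine nitrogen gives a 1.2-fold lower number from compound 2 to compound 4 (0.07 log units; within the scatter) in this assay. Compound 2 and compound 4 therefore read level, and this pair has a number at both ends, so the size of a change to the aryl group on this nitrogen can be read directly, with no shift beyond the scatter for this exchange. Nothing at hand bears on why these two aryl groups read alike.

This exchange alters both the substituent and its place on the phenyl ring, so neither can be read alone. Going by these compounds, whether a ring carrying an amine or a carboxylic acid, or a saturated chain on the amine nitrogen in place of the phenyl ring, would move the reading beyond the scatter remains open.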